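This account rests on a few compounds, and the source may have more. Where it says the series, first, only, none or still open, it means among the compounds named here.

Compound 1 `C[C@H]1O[C@@H]([C@@H]2CCCN2C)C[S@@+]1[O-]` and compound 2 `C[C@@H]1O[C@H]([C@H]2CCCN2C)C[S@+]1[O-]` are the two measured compounds.

In an assay on CHO cells for binding affinity to muscarinic acetylcholine receptor M5 (Homo sapiens) (on this read-out lower numbers stand for stronger inhibition and higher numbers for weaker inhibition), compound 1 gives < 100000 nM, a limit of the assay rather than a number. In this assay compound 2 gives < 100000 nM, likewise a limit. On these data alone, the step that the two limits leave unreadable from compound 1 to compound 2 therefore cannot be read, and its size is unknown. For the measured compounds named here, compound 2 thus stands only at a limit, and the one other value shown sits at the same limit.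

Compound 3 `C[C@H]1O[C@@H]([C@H]2CCCN2C)C[S@@+]1[O-]` differs from compound 2 by the two compounds have the same atoms and bonds and differ only in configuration as drawn: 3 of 4 stereo elements differ; a stereocentre at a saturated ring carbon is drawn R in compound 2 and S in compound 3; a stereocentre at a saturated ring carbon is drawn R in compound 2 and S in compound 3; a stereocentre at a sulfur is drawn S in compound 2 and R in compound 3. Going by the values given here, the only measured step that bears on a change of configuration alone is the one from compound 1 to compound 2, and because of the limit of < 100000 nM in this assay, at which 2 of the 2 values shown sit, it says nothing about size or direction. Compound 3 is therefore expected to behave like compound 2, with an expected step that the limit leaves unreadable from compound 2 to compound 3 in this assay. Compound 3 is estimated at 30000 nM, within a range from 3000 nM to 100000 nM, with a limit again the most likely outcome.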

Compound 3, inhibition constant: < 100000 nM
Compound 3 gave a limit, no number (the forecaster's own chance of this, stated with the estimate: 70%); the middle value does not contradict the limit.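

In this assay compound 3 gives < 100000 nM as a limit and not a number. For the compounds shown here, compounds 1 and 2 also stand at limits, so no step among compounds 1, 2 and 3 can be read. On these data alone, whether configuration alters binding affinity, and in which direction or by how much, stays open.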